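The compounds below may be only part of what the source reports. "The series", "measured", "known", "first", "only" and "open" are said of these compounds alone.

Measured compounds:
Compound 1, `COC(=O)c1c(-c2ccc(OCc3ccccc3)cc2)oc2ccccc2c1=O`, in a functional assay on MCF7 cells (Homo sapiens) for cytotoxicity, read by MTT assay, with a stated time of 6 days (on this read-out lower numbers stand for an effect already at smaller amounts and higher numbers for an effect only at larger amounts of compound), gives > 25 ug/mL, a limit of the assay.
Compound 2, `COC(=O)c1c(-c2ccc(OCc3ccccc3)cc2)oc2ccc(OC)cc2c1=O`, in this assay gives > 25 ug/mL, a limit.
Compound 3, `COc1ccc2c(=O)cc(-c3cc(OC)c(OC)c(OC)c3)oc2c1`, in this assay gives > 25 ug/mL, a limit.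

Compound 2 differs from compound 1 by methoxy in place of hydrogen on an aromatic carbon. The step that the two limits leave unreadable from compound 1 to compound 2; all three values sit at the same limit (the limit of > 25 ug/mL in this assay, at which 3 of the 3 values shown sit). The difference between the core of compound 3 and that of compound 1 is not broken down here.

Compound 4, `COc1cc(-c2cc(=O)c3ccc(OC)c(OC)c3o2)cc(OC)c1OC`, is not yet measured and differs from compound 3 by methoxy in place of hydrogen on an aromatic carbon. This is the same kind of change as from compound 1 to compound 2, but the place is not the same: here the methoxy enters ortho to a fused ring, ortho to a methoxy group and meta to a fused ring, whereas in compound 2 it sits meta to a fused ring and para to a fused ring.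

For compound 4 a step that the limit leaves unreadable from compound 3 to compound 4 is expected in this assay, resting on the unreadable step from compound 1 to compound 2, a step that the two limits leave unreadable from compound 1 to compound 2, and on compound 3 sitting at the limit (the limit of > 25 ug/mL in this assay, at which 3 of the 3 values shown sit). The estimate for compound 4 is 30 ug/mL, with a range from 8 ug/mL to 100 ug/mL.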

Compound 4, concentration for half-maximal effect: > 25 ug/mL
Compound 4 was reported as a limit; the forecaster's own chance of this, stated with the estimate: 70%; the middle value is on the limit's open side.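

In this assay compound 3 and compound 4 both stand at a limit, and no step between them can be read: the limit of > 25 ug/mL in this assay, at which 4 of the 4 values shown sit.

The compounds shown leave open whether methoxy in place of hydrogen shifts the read-out at all, at either place.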